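The source may report more compounds than this note shows. Statements on the series, on what has been measured and on what is new or still open speak of the compounds shown alone.

Measured compounds:
compound 1 `O=C([C@H]1Cc2cc(Cl)cc(-c3ccnc4ccsc34)c2O1)N1CCNCC1` — 90 nM
compound 2 `Cc1cc(Cl)cc(-c2ccnc3cc(CN4C(=O)CCC4=O)sc23)c1CN1[C@@H](C)CNC[C@@H]1C` — 0.32 nM

Of the compounds shown here, two have been measured in an assay on isolated protein for inhibition of ubiquitin carboxyl-terminal hydrolase 7 (Homo sapiens), read by fluorescence, with stated times of 30 min and 1 h; on this read-out lower numbers stand for stronger inhibition and higher numbers for weaker inhibition. Compound 1 `O=C([C@H]1Cc2cc(Cl)cc(-c3ccnc4ccsc34)c2O1)N1CCNCC1` gives 90 nM, the highest of the two numbers, and therefore the weaker inhibitor of the pair. Compound 2 `Cc1cc(Cl)cc(-c2ccnc3cc(CN4C(=O)CCC4=O)sc23)c1CN1[C@@H](C)CNC[C@@H]1C` gives 0.32 nM, a far lower number that lies well beyond the scatter of repeated measurements, but compound 2 differs from compound 1 in several places at once, so no single structural change can be read from that gap.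

The new compound 3 `Cc1cc2nccc(-c3cc(Cl)cc4c3O[C@@H](C(=O)N3CCNCC3)C4)c2s1` takes a single, small step away from compound 1: methyl in place of hydrogen on an aromatic carbon. For the measured compounds named here, no measured pair shows this exact change, so the expected size of the step rests on the compounds above alone. Compound 2, with its much lower number 0.32 nM, carries a substituent at the same aromatic carbon of the five-membered ring, which hints that a group at that place is tolerated. A modest improvement is therefore expected, a 2.6-fold lower number from compound 1 to compound 3 (0.41 log units; beyond the scatter), rather than a large one. For compound 3 the estimated value in this assay is 35 nM, with a likely range from 10 nM to 120 nM.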

Compound 3, half-maximal inhibitory concentration: 130 nM
Beside the measured number, compound 3's estimate is 3.7-fold (0.57 log units) below it; measured number above the stated range.
By their numbers in this assay, from the lowest: compound 2; then compounds 1 and 3 (each within the scatter of the next).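

In this assay, methyl in place of hydrogen on an aromatic carbon of the five-membered ring, next to the ring sulfur, gives a 1.4-fold higher number from compound 1 to compound 3 (0.16 log units; within the scatter), so this single change produces no difference that can be told apart from repeat-measurement noise. For the compounds shown here, this is the first direct reading of this position with everything else in the molecule held constant, and it shows that the core of compound 1 can carry a methyl group here without a clear change in the number. No measurement available here gives a reason for this result.

A single methyl group says little about what larger groups would do at this carbon, so an ethyl group, an aminomethyl group or a carboxylic acid there could give a very different number or much the same one. As far as these compounds go, compound 2 also carries a substituent at this carbon, but it differs from compound 1 in several other places too, so what that substituent contributes to its number remains open.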